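The compounds below may be only part of what the source reports. "The series", "measured", "known", "first", "only" and "open" are said of these compounds alone.

Three compounds share one core and differ only in the group on a carbonyl carbon. Compound 1 `O=C(OC1CCC(CN2CCN(c3cc(=O)c4cc(C(F)(F)F)cc([N+](=O)[O-])c4s3)CC2)CC1)C1CCCCC1` carries a cyclohexyl there, compound 2 `O=C(OC1CCC(CN2CCN(c3cc(=O)c4cc(C(F)(F)F)cc([N+](=O)[O-])c4s3)CC2)CC1)c1ccco1` a furan-2-yl, and compound 3 `O=C(OC1CCC(CN2CCN(c3cc(=O)c4cc(C(F)(F)F)cc([N+](=O)[O-])c4s3)CC2)CC1)c1ccncc1` a pyridin-4-yl. In an ADME assay on cells (Hepatocyte, Mus musculus) for metabolic stability, with a stated time of 30 min (on this read-out higher numbers stand for a more stable compound and lower numbers for a less stable compound), compound 1 gives 1.2%, compound 2 gives 0.6%, and compound 3 gives 1.4%. Compound 3 thus holds the highest of the three numbers, yet all three sit close together: a number 0.2 percentage points higher from compound 1 to compound 3 (within the scatter) and a number 0.8 percentage points higher from compound 2 to compound 3 (within the scatter), so none of the three can be called more stable than another.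

Compound 4 `CC(=O)OC1CCC(CN2CCN(c3cc(=O)c4cc(C(F)(F)F)cc([N+](=O)[O-])c4s3)CC2)CC1` has not yet been measured. It differs from compound 3 in one place: methyl in place of pyridin-4-yl on a carbonyl carbon. The change again sits on a carbonyl carbon whose other neighbour is oxygen next to a carbonyl group, the same place where the three measured steps occurred. Every one of those steps stayed within the scatter, including a number 0.6 percentage points lower from compound 1 to compound 2 (within the scatter). On that basis no step beyond the scatter is expected from compound 3 to compound 4 in this assay. The expected step is a number 0.1 percentage points higher from compound 3 to compound 4 (within the scatter). For compound 4 the estimate in this assay is 1.5%, with a range from 0.3% to 6%.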

Compound 4, percent of the compound remaining: 0%
Compound 4: the middle estimate sits 1.5 percentage points above what was measured; the measured number lies below the stated range.
By their numbers in this assay, from the lowest: compounds 4, 2, 1 and 3 (each within the scatter of the next).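

Trimming the group on the carbonyl carbon down to methyl, with its single heavy atom in place of the six of pyridin-4-yl, leaves the percent remaining in this assay inside the usual scatter for every comparison available (a number 1.4 percentage points lower from compound 3 to compound 4 (within the scatter); a number 0.6 percentage points lower from compound 2 to compound 4 (within the scatter); a number 1.2 percentage points lower from compound 1 to compound 4 (within the scatter)). The earlier compounds shown here all carried a ring at this position, so compound 4 adds something they could not show: with no ring there at all, compound 4 gives 0%, and this reading cannot be told apart from those of the three ring-bearing compounds. No supporting measurement is available to explain why these four groups read alike.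

From the compounds shown here alone, all four numbers lie so close together that this series offers no group at this position that separates from the others, so it remains open whether a longer chain such as butyl, or an amine attached to the same carbonyl carbon, would move the number beyond the scatter. Going by these compounds, it also remains open whether any change elsewhere on the shared core, rather than on this carbonyl carbon, would shift the reading in this hepatocyte test.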